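Taking one methyl off a dimethylphenyl sulfonamide

A few compounds are considered here, and "the series" means these few. Any claim that something is new, unique, unknown or untested is made for them only; others in the source may bear on it.

In a functional assay on HT-29 cells (Homo sapiens) for antiproliferative activity, read by sulforhodamine B assay, with a stated time of 48 h (on this read-out higher numbers stand for weaker inhibition and lower numbers for stronger inhibition), compound 1 `Cc1cccc(NS(=O)(=O)c2ccc(N3CCNC3=O)cc2)c1C` gives 190 nM while compound 2 `Cc1ccc(C)c(NS(=O)(=O)c2ccc(N3CCNC3=O)cc2)c1` gives 46 nM and so holds the lower of the two numbers. Going by the values given here, the one measured step is a 4.1-fold lower number from compound 1 to compound 2 (0.62 log units; beyond the scatter) and it exchanges 2,3-dimethylphenyl for 2,5-dimethylphenyl on the sulfonamide nitrogen. Compound 3 `Cc1ccccc1NS(=O)(=O)c1ccc(N2CCNC2=O)cc1` has not yet been measured in this assay and departs from compound 2 by hydrogen in place of methyl on an aromatic carbon in the change of 2,5-dimethylphenyl to 2-methylphenyl, with hydrogen in place of methyl on an aromatic carbon. Among the compounds with values here, no measured pair shows the loss of a methyl, so the evidence is indirect. Within the data shown here, the step of a 4.1-fold lower number from compound 1 to compound 2 (0.62 log units; beyond the scatter) shows only that the number can shift beyond the scatter when the position of one methyl differs. A modest step toward weaker inhibition therefore seems likelier than none, of about the same size as that one. The expected change is a 3.3-fold higher number from compound 2 to compound 3 (0.51 log units; beyond the scatter) in this estimate. For compound 3 the estimated value is 150 nM with an expected range from 50 nM to 450 nM in this assay.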

Compound 3, half-maximal inhibitory concentration: 200 nM
Compound 3: the middle estimate sits 1.3-fold (0.12 log units) below what was measured; the measured number falls inside the stated range.
By their numbers in this assay, from the lowest: compound 2; then compounds 1 and 3 (each within the scatter of the next).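

In this assay the methyl that stands meta to a large group and para to a methyl group proves to matter: taking it off gives a 4.3-fold higher number from compound 2 to compound 3 (0.64 log units; beyond the scatter) and leaves 2-methylphenyl in place of 2,5-dimethylphenyl. Making the same exchange of hydrogen for methyl on 2,3-dimethylphenyl gives a 1.1-fold higher number from compound 1 to compound 3 (0.02 log units; within the scatter) and so produces no readable difference. Among these three compounds, then, a second methyl goes with the lower number only in 2,5-dimethylphenyl, while compound 1, with its second methyl elsewhere on the ring, cannot be told apart from compound 3, and nothing available here explains why the two places differ.

The compounds shown leave open whether the place held by the second methyl in compound 2 is specific to methyl or would also accept chlorine, methoxy, an amine or a longer chain such as ethyl. They also leave open whether that methyl would count in the same way without the methyl kept in 2-methylphenyl, for all three compounds carry that group.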